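The source may hold more compounds than are shown below. What is called first, only, known or untested is meant among the compounds shown, and "the series" means these compounds.

Working notes on the series. The shared core is that of compound 1 `O=S1(=O)C=C(OCc2ccccc2)C(Cc2ccccc2)(Cc2ccccc2)O1`, which in an ADME assay on HEL cells (Homo sapiens) for cytotoxicity, with a stated time of 3 days (on this read-out higher numbers stand for lower toxicity in this test and lower numbers for higher toxicity in this test), gives 200000 nM. Compound 3 `CC(C)C1(Cc2ccccc2)OS(=O)(=O)C=C1OCc1ccccc1` is recorded in this assay only as a limit, at >= 80000 nM. The step that the limit leaves unreadable from compound 1 to compound 3 therefore cannot be sized. Compound 2 `CCC1(Cc2ccccc2)OS(=O)(=O)C=C1OCc1ccc(Cl)cc1` also stands only at a limit in this assay, at >= 50000 nM. Among the three values shown, compound 2 is thus one of two that are limits rather than numbers, and no measured step starts or ends at compound 2.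

Compound 4 `CCC1(Cc2ccccc2)OS(=O)(=O)C=C1OCC1CCCCC1` differs from compound 2 by cyclohexyl in place of 4-chlorophenyl on a saturated chain carbon bound to an oxygen on an unsaturated carbon. Going by the values given here, no measured step bears on this change: the only step in the set, from compound 1 to compound 3, is unreadable, and the two limits the limit of >= 50000 nM in this assay, at which 1 of the 3 values shown sits, and the limit of >= 80000 nM in this assay, at which 1 of the 3 values shown sits, give no size to compare against. With nothing pointing either way, no movement beyond the scatter is expected from compound 2 to compound 4, a step that the limit leaves unreadable from compound 2 to compound 4. Compound 4 is therefore estimated at 100000 nM, within 30000 nM to 300000 nM, with a real chance that the assay again reports only a limit.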

Compound 4, minimum cytotoxic concentration: >= 200000 nM
Compound 4 was reported as a limit; the forecaster's own chance of this, stated with the estimate: 70%; middle value at least 2.0-fold (0.30 log units) away from the limit.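

In this assay compound 4 is recorded only as a limit, >= 200000 nM. Going by these compounds alone, compound 2 is also only a limit, >= 50000 nM, so no step from compound 2 to compound 4 can be read. The compounds shown leave open whether cyclohexyl in place of 4-chlorophenyl changes the minimum cytotoxic concentration at all.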